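Cytotoxicity notes: from compound 3 to compound 4

The source may report more compounds than this note shows. Statements on the series, on what has been measured and on what is new or still open speak of the compounds shown alone.

Measured so far in an ADME assay on Vero 76 cells (Chlorocebus sabaeus) for cytotoxicity, read by microscopy; on this read-out lower numbers stand for higher toxicity in this test and higher numbers for lower toxicity in this test (half-maximal cytotoxic concentration):
- compound 1 `NCCCNC(=O)[C@@]12C[C@@H]1[C@@H](n1cnc3c(NC(C4CC4)C4CC4)nc(Cl)nc31)[C@H](O)[C@@H]2O` gives > 50000 nM (a limit)
- compound 2 `CC(C)[C@@H](Nc1nc(I)nc2c1ncn2[C@H]1[C@H](O)[C@H](O)[C@]2(CO)C[C@H]12)C1CC1` gives 100000 nM (a number)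
- compound 3 `OC[C@@]12C[C@@H]1[C@@H](n1cnc3c(NCc4ccccc4)nc(Cl)nc31)[C@H](O)[C@@H]2O` gives > 100000 nM (a limit)

Compound 3 gives only a limit (> 100000 nM) and no number. Compound 4 (`OC[C@@]12C[C@@H]1[C@@H](n1cnc3c(NC(C4CCC4)C4CCC4)nc(Cl)nc31)[C@H](O)[C@@H]2O`) has dicyclobutylmethyl in place of benzyl on a nitrogen on an aromatic ring. Going by the values given here, no two measured compounds differ in one place, so no measured step guides this change. Among the compounds with values here, compound 2, the only one with a number (100000 nM), gives the one reference for an expectation. The expected step is an at least 1.2-fold lower number from compound 3 to compound 4 (0.09 log units; that floor lies within the scatter) (none beyond the scatter). Compound 4 is estimated at 80000 nM (expected range 30000 nM to 100000 nM).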

Compound 4, half-maximal cytotoxic concentration: 50000 nM
For compound 4 the middle estimate is 1.6-fold (0.20 log units) above the measured one; measured number inside the range.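

In this assay, the change at this position can now be read as a step: an at least 2.0-fold lower number from compound 3 to compound 4 (0.30 log units; that floor lies within the scatter). Its floor lies within the usual scatter, so replacing benzyl with dicyclobutylmethyl on this nitrogen shows no firm change in this read-out. The step is only a floor because compound 3 gives a limit and not a number: the limit of > 100000 nM in this assay, at which 1 of the 4 values shown sits.

The compounds shown leave open how large the step really is. They also leave open how a longer chain ending in an amine at this nitrogen would read in this assay.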